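A few compounds are considered here, and "the series" means these few. Any claim that something is new, unique, unknown or untested is made for them only; others in the source may bear on it.

Measured in a functional assay on HepG2 cells (Homo sapiens) for inhibition, with a stated time of 72 h; a lower number here means a stronger inhibitor, a higher number a weaker inhibitor:
- compound 1 `COc1ccc(NC(=O)Nc2nc(Sc3c[nH]c4ccccc34)cc(N3CCCCC3)n2)cc1`: 17100 nM
- compound 2 `O=C(Nc1ccc(Cl)cc1)Nc1nc(Sc2c[nH]c3ccccc23)cc(N2CCCC2)n1`: 7870 nM
- compound 3 `COc1ccc(NC(=O)Nc2nc(Nc3cc(OC)cc(OC)c3)cc(Sc3c[nH]c4ccccc34)n2)cc1`: 17400 nM

Compound 1 stands level with compound 3, and only compound 2 gives a clearly lower number. Compound 4 `O=C(Nc1ccccc1)Nc1nc(Sc2c[nH]c3ccccc23)cc(N2CCCCC2)n1` differs from compound 1 by one change: hydrogen in place of methoxy on an aromatic carbon. This puts hydrogen in place of methoxy on an aromatic carbon, para to a large group. Among the measured compounds shown here, no measured step touches this place. For the measured compounds named here, the only single-place step, a 1.0-fold higher number from compound 1 to compound 3 (0.01 log units; within the scatter), concerns another group. Compound 2 differs from compound 1 in more than one place, so its gap says little about this change. No step beyond the scatter is therefore expected in this assay. The expected step is a 1.2-fold lower number from compound 1 to compound 4 (0.09 log units; within the scatter). For compound 4 the estimated value is 14000 nM, with an expected range from 6500 nM to 30000 nM.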

Compound 4, half-maximal inhibitory concentration: 20900 nM
Estimate against measurement, compound 4: 1.5-fold (0.17 log units) below; the measured number falls inside the stated range.
By their numbers in this assay, from the lowest: compound 2; then compounds 1, 3 and 4 (each within the scatter of the next).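

Among the compounds shown here, compound 1 and compound 4 stand level in this assay (a 1.2-fold higher number from compound 1 to compound 4 (0.09 log units; within the scatter)), which gives the first reading at this place, on the aromatic carbon para to a large group. With the rest of compound 1 kept, 4-methoxyphenyl can give way to phenyl without a step beyond the scatter. Nothing at hand explains this result. From the compounds shown here alone, whether an amine or a carboxylic acid at this place would also stay level remains open, as does whether a step beyond the scatter can arise here at all.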